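The source may report more compounds than this note shows. Statements on the series, on what has been measured and on what is new or still open speak of the compounds shown alone.

Measured compounds:
- compound 1, `CNC(=O)c1cc(C(=O)NCCC[C@H]2OC[C@H](N)CO2)cc2c1OC[C@H]2c1ccccc1`: in a physicochemical assay for lipophilicity, at pH 7.4 (on this read-out higher numbers stand for higher lipophilicity and lower numbers for lower lipophilicity), compound 1 gives 2.6
- compound 2, `CNC(=O)c1cc(C(=O)N[C@H]2C[C@@H]2C)cc2c1OC[C@H]2c1ccccc1`: in this assay compound 2 gives 4.5

Among the measured compounds shown here, compound 2 stands highest of the two numbers; its nearest neighbour is compound 1, and the one step between them, a number 1.90 log units higher from compound 1 to compound 2 (beyond the scatter), is large and beyond the scatter.

Compound 3, `CNC(=O)c1cc(C(=O)N[C@H]2[C@@H]3C[C@@H](O)C[C@@H]32)cc2c1OC[C@H]2c1ccccc1`, is not yet measured. It differs from compound 2 in one place: a group of 7 heavy atoms (6 carbon, 1 oxygen; one three-membered non-aromatic ring of carbon only, one five-membered non-aromatic ring of carbon only) in place of a group of 4 heavy atoms (4 carbon; one three-membered non-aromatic ring of carbon only), on an amide-type nitrogen. The entering group carries 1 hydrogen-bond donor and 1 hydrogen-bond acceptor where the leaving 2-methylcyclopropyl carries none, and it is larger by three heavy atoms.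

For the measured compounds named here, the only step that bears on this change is a number 1.90 log units higher from compound 1 to compound 2 (beyond the scatter), which also swaps the group on the amide-type nitrogen; there the compound carrying the larger group with hetero atoms gave the much lower number. The present change is smaller in both respects, so a step downward in this assay is expected from compound 2 to compound 3, of moderate size, a number 0.50 log units lower from compound 2 to compound 3 (beyond the scatter), though a result within the scatter cannot be excluded. For compound 3 the estimated value in this assay is 4, expected to fall between 3.3 and 4.7.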

Compound 3, distribution coefficient: 2.9
Compound 3: the middle estimate sits 1.10 log units above what was measured, and the stated range ends above it.
By their numbers in this assay, from the lowest: compounds 1 and 3 (each within the scatter of the next); then compound 2.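

In this assay, among the compounds shown here, three added heavy atoms with one hydrogen-bond donor and one hydrogen-bond acceptor on the amide-type nitrogen are enough for a large step, a number 1.60 log units lower from compound 2 to compound 3 (beyond the scatter), so the step at this position is not tied to a group as large as the one in compound 1. The second comparison, a number 0.30 log units higher from compound 1 to compound 3 (within the scatter), places two quite different groups within the scatter of each other: one with a six-membered ring bearing two hetero atoms and a nitrogen, the other with only carbon rings and one oxygen, so the two groups cannot be told apart on this read-out. No measurement available here accounts for either step.

Going by these compounds, it remains open whether the oxygen or the added five-membered ring carries the step, which the same two-ring group with a hydrogen in place of the hydroxyl would separate. On these data alone, how an amine, a carboxylic acid or a methoxy at that spot would read in this assay also remains open, as does whether the low end of these values can be passed with such a group.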